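This account rests on a few compounds, and the source may have more. Where it says the series, first, only, none or still open, it means among the compounds named here.

Among the measured compounds shown here, compound 2 `NS(=O)(=O)c1ccc(NC(=S)Nc2ccc3ncnc(Nc4cccc(C(F)(F)F)c4)c3c2)cc1` is the only compound here with an actual number in a functional assay on A549 cells (Homo sapiens) for antiproliferative activity, read by MTT assay, with a stated time of 72 h (a lower number here means a stronger inhibitor, a higher number a weaker inhibitor), where compound 2 gives 10100 nM. Compound 1 `NS(=O)(=O)c1ccc(NC(=S)Nc2ccc3ncnc(Nc4ccc(F)c(Cl)c4)c3c2)cc1` reaches only the limit of the assay, > 40000 nM, which is the limit of > 40000 nM in this assay, at which 1 of the 2 values shown sits. Compound 3 `NS(=O)(=O)c1ccc(NC(=S)Nc2ccc3ncnc(Nc4ccc(Cl)c(C(F)(F)F)c4)c3c2)cc1` differs from compound 2 by chloro in place of hydrogen on an aromatic carbon. For the measured compounds named here, the one measured step, an at least 3.9-fold lower number from compound 1 to compound 2 (0.59 log units; beyond the scatter), altered the same ring but exchanged two groups at once, so it bears only loosely on adding a single chloro. The expected change is small, roughly a 1.5-fold higher number from compound 2 to compound 3 (0.17 log units; within the scatter). Compound 3 is therefore estimated at 15000 nM, within 4000 nM to 45000 nM.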

Compound 3, half-maximal inhibitory concentration: 4500 nM
The estimate for compound 3 lay 3.3-fold (0.52 log units) above the measured number, and the stated range covers the measured number.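

In this assay, chloro on the aromatic carbon ortho to the trifluoromethyl group and para to a large group gives a 2.2-fold lower number from compound 2 to compound 3 (0.35 log units; beyond the scatter), so this position accepts chloro, with a modest gain. Exchanging the whole 3-chloro-4-fluorophenyl group for 4-chloro-3-(trifluoromethyl)phenyl gives an at least 8.8-fold lower number from compound 1 to compound 3 (0.94 log units; beyond the scatter). That step has no upper end, as compound 1 gives a limit, not a number: the limit of > 40000 nM in this assay, at which 1 of the 3 values shown sits.

From the compounds shown here alone, whether bromo, methoxy or an amine at this position would do better remains open. So does whether chloro gives the same step on a ring without trifluoromethyl.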